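Swapping a Benzyl Arm for a Furan Arm

This account rests on a few compounds, and the source may have more. Where it says the series, first, only, none or still open, it means among the compounds named here.

Compound 1 `COc1cccc(CNCCCNc2ccnc3cc(-c4cc(C(F)(F)F)cc(C(F)(F)F)c4)ccc23)c1O` is examined in a physicochemical assay for acid dissociation, where compound 1 gives 9.47. Two relatives sit level with it at the digits printed: compound 2 `COc1ccc(F)cc1CNCCCNc1ccnc2cc(Cc3ccc(C#N)cc3)ccc12` gives 9.47 and compound 3 `COc1cccc(CNCCCNc2ccnc3cc(Cc4ccc(F)cc4Cl)ccc23)c1O` gives 9.47, all three within the scatter of one another. The next compound, compound 4 `FC(F)(F)c1cc(-c2ccc3c(NCCCNCc4ccco4)ccnc3c2)cc(C(F)(F)F)c1`, differs from compound 1 in one place (furan-2-yl in place of 2-hydroxy-3-methoxyphenyl on a saturated chain carbon bound to an amine nitrogen). Among the compounds with values here, no measured pair in this set spans that change, so the step is open. Compounds 2 and 3 show the chain amine holding its value when the aryl group attached to the saturated chain carbon changes, yet furan-2-yl is a larger departure, and a small downward step is expected from compound 1 to compound 4 of a number 0.27 log units lower from compound 1 to compound 4 (within the scatter), near the edge of the scatter. Compound 4 is expected to give 9.2, between 8.7 and 9.7.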

Compound 4, acid dissociation constant: 9.47
For compound 4 the middle estimate is 0.27 log units below the measured one, within the range that was stated.
By their numbers in this assay, from the lowest: compounds 1, 2, 3 and 4 (each within the scatter of the next).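

In this assay, furan-2-yl in place of 2-hydroxy-3-methoxyphenyl on a saturated chain carbon bound to an amine nitrogen gives no change at the digits printed from compound 1 to compound 4 (within the scatter) for this first measured step at this place. The entering group has 5 heavy atoms against 9 and 0 hydrogen-bond donors against 1, yet the printed value stays the same. No measurement shown here accounts for this result. Still open, from the compounds shown here alone, is whether a pyridine ring, or an aryl group carrying a carboxylic acid or an amine, would shift the value at this place.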